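The compounds below may be only part of what the source reports. "The series", "measured", "known", "first", "only" and "open" are said of these compounds alone.

Compound 1, `CC1(C)C=C(n2ccccc2=O)c2cc(C(=O)c3cccs3)ccc2O1`, gives 6.4 in a functional assay (aorta) with Rattus norvegicus as the target; on this read-out lower numbers stand for lower potency and higher numbers for higher potency (the scale is a negative logarithm).
Compound 2, `Cc1ccccc1C(=O)c1ccc2c(c1)C(n1ccccc1=O)=CC(C)(C)O2`, gives 6.83 in this assay.
Compound 3, `CC1(C)C=C(n2ccccc2=O)c2cc(C#N)ccc2O1`, gives 7.67 in this assay.

Compound 3 stands highest of the three, with compound 2 nearest at a step of a number 0.84 log units higher from compound 2 to compound 3 (beyond the scatter) and compound 1 furthest at a number 1.27 log units higher from compound 1 to compound 3 (beyond the scatter). Compound 4, `CC1(C)C=C(n2ccccc2=O)c2cc(-c3ccncc3)ccc2O1`, has not yet been measured. It differs from compound 3 in one place: pyridin-4-yl in place of cyano on an aromatic carbon.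

Within the data shown here, no measured step swaps a cyano for an aromatic ring, so the expectation rests on indirect evidence. The two steps that reach compound 3 both replace a large group at that same aromatic carbon by the small cyano and both raise potency, one by a number 1.27 log units higher from compound 1 to compound 3 (beyond the scatter) and the other by a number 0.84 log units higher from compound 2 to compound 3 (beyond the scatter). Going back from cyano to a bulkier group, here a pyridin-4-yl ring, is therefore expected to lower potency, though the new group is not a carbonyl and is smaller than those removed, so a modest drop seems more likely than a large one. The estimated step is a number 0.67 log units lower from compound 3 to compound 4 (beyond the scatter). Compound 4 is estimated to give 7 in this assay, most likely between 6.3 and 7.7.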

Compound 4, logarithm of the reciprocal of the active concentration, log(1/C): 6.68
For compound 4 the middle estimate is 0.32 log units above the measured one; the range from low to high includes it.
By their numbers in this assay, from the lowest: compounds 1, 4 and 2 (each within the scatter of the next, the first and the last beyond it); then compound 3.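

In this assay, the group on this aromatic carbon can be an aromatic ring without a carbonyl, and cyano still gives the higher number: the change to pyridin-4-yl brings a number 0.99 log units lower from compound 3 to compound 4 (beyond the scatter) and so extends the advantage of cyano to a third, different group. The other two comparisons place pyridin-4-yl close to both carbonyl-linked groups, with a number 0.15 log units lower from compound 2 to compound 4 (within the scatter) and a number 0.28 log units higher from compound 1 to compound 4 (within the scatter) even though compound 1 and compound 2 stand apart beyond the scatter. No measurement here explains these differences.

The compounds shown leave open whether the ring nitrogen of pyridin-4-yl matters, which a phenyl or pyridin-3-yl group on the same carbon would test. They also leave open how groups with few heavy atoms, such as a methyl, a chlorine atom or an amine, would compare with cyano.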